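Does a Shorter Chain Change Cell Inhibition?

This account rests on a few compounds, and the source may have more. Where it says the series, first, only, none or still open, it means among the compounds named here.

The measured compounds and their values are:

Compound 1, `CCCCCCCCCCn1cc(/C=C/C(=O)c2ccc(NC(=O)CN3CCC(Cc4ccccc4)CC3)cc2)nn1`, gives 33300 nM in a functional assay on SK-N-SH cells (Homo sapiens) for inhibition, read by MTT assay; a lower number here means a stronger inhibitor, a higher number a weaker inhibitor.
Compound 2, `CCCCCCCCCCn1cc(/C=C/C(=O)c2ccc(NC(=O)CBr)cc2)nn1`, gives 8680 nM in this assay.
Compound 3, `CCCCCCCCn1cc(/C=C/C(=O)c2ccc(NC(=O)CBr)cc2)nn1`, gives 8460 nM in this assay.

Compounds 2 and 3 share one core and differ in a single place: hydrogen in place of ethyl on a saturated chain carbon, eight bonds along the chain from an aromatic nitrogen. This change made a 1.0-fold lower number from compound 2 to compound 3 (0.01 log units; within the scatter), so the two values tell the same story and no order between them can be claimed.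

Compound 1 carries a different core from compound 2; the difference between the two cores is not broken down here. What the values show is that compound 1 stands highest of the three, and its gap to compound 2 and to compound 3 lies beyond the scatter, so compound 1 is the weakest inhibitor among the measured set.

Compound 4, `CCCCCCCCn1cc(/C=C/C(=O)c2ccc(NC(=O)CN3CCC(Cc4ccccc4)CC3)cc2)nn1`, has not been measured. It relates to compound 1 exactly as compound 3 relates to compound 2: hydrogen in place of ethyl on a saturated chain carbon, eight bonds along the chain from an aromatic nitrogen. The place of the change is the same in both pairs, so this is the same change made on the core of compound 1.

The step from compound 1 to compound 4 in this assay is expected to be a 1.0-fold lower number from compound 1 to compound 4 (0.00 log units; within the scatter), because the same change gave a 1.0-fold lower number from compound 2 to compound 3 (0.01 log units; within the scatter) on the other core. Compound 4 is therefore estimated at 33000 nM, expected to fall between 15000 nM and 70000 nM.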

Compound 4, half-maximal inhibitory concentration: 57000 nM
The estimate for compound 4 lay 1.7-fold (0.24 log units) below the measured number; the range from low to high includes it.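

Placing hydrogen where ethyl stood, on a saturated chain carbon, eight bonds along the chain from an aromatic nitrogen, gave a 1.7-fold higher number from compound 1 to compound 4 (0.23 log units; within the scatter) in this assay, so on the core of compound 1 this change produced no step that can be told apart from the ordinary spread of repeated measurements. The earlier step on the other core was also within that spread, and the two steps cannot be told apart from each other: the same change on two cores in this assay, a 1.0-fold lower number (0.01 log units; within the scatter) from compound 2 to compound 3 and a 1.7-fold higher number (0.23 log units; within the scatter) from compound 1 to compound 4, 1.8-fold (0.24 log units) apart, within the scatter of two such steps. This shows that, for these two cores in this one assay, the change carried over from one core to the other without a detectable difference, but it rests on a single pair per core, so it does not show that the change would behave the same way on any further core, nor does it rule out a small real effect hidden within the scatter.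

The compounds shown leave open what a longer chain would do on either core, since only this one change in chain length can be read here. They also leave open whether a hydroxyl group or a carboxylic acid placed on the same chain carbon would carry over between the two cores in the same way.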